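The compounds below may be only part of what the source reports. "The series", "measured", "known", "first", "only" and "open" are said of these compounds alone.

Series notes. Compound 1 `COc1ccc(Oc2ccccc2-c2ccsc2S(=O)(=O)N2CCN(C(=O)Nc3ccc([N+](=O)[O-])cc3)CC2)cc1OC` carries a 3,4-dimethoxyphenoxy group on the shared core; compound 3 `O=C(Nc1ccc([N+](=O)[O-])cc1)N1CCN(S(=O)(=O)c2sccc2-c2ccccc2Oc2ccc(O)c(O)c2)CC1` is the same molecule after (3,4-dihydroxyphenyl in place of 3,4-dimethoxyphenyl on an oxygen on an aromatic ring). In an ADME assay on HEK-293T cells (Homo sapiens) for cytotoxicity, read by CCK-8 assay, with a stated time of 48 h (on this read-out lower numbers stand for stronger inhibition and higher numbers for weaker inhibition), compound 1 reports only the assay limit of > 20000 nM. In this assay compound 3 likewise reaches only the limit, > 20000 nM. The step that the two limits leave unreadable from compound 1 to compound 3 therefore cannot be sized. Both values sit at the limit of > 20000 nM in this assay, at which 2 of the 3 values shown sit. Going by the values given here, compound 2 `COc1ccc(Oc2ccc(C(C)C)cc2-c2ccsc2S(=O)(=O)NCCNC(=S)Nc2cc(C(F)(F)F)cc(C(F)(F)F)c2)cc1OC` gives 10200 nM in this assay, the one number in the set. The difference between the core of compound 2 and the core of compound 1 is not broken down here. Compound 4 `CC(C)c1ccc(Oc2ccc(O)c(O)c2)c(-c2ccsc2S(=O)(=O)NCCNC(=S)Nc2cc(C(F)(F)F)cc(C(F)(F)F)c2)c1` is the unmeasured partner of compound 2, made by 3,4-dihydroxyphenyl in place of 3,4-dimethoxyphenyl on an oxygen on an aromatic ring, the same change as from compound 1 to compound 3, at a place described in the same words. That earlier step gives no size, so the expected step of a 1.2-fold higher number from compound 2 to compound 4 (0.07 log units; within the scatter) rests only on compound 2 at 10200 nM and is set near zero with wide bounds. Compound 4 is expected to give about 12000 nM in this assay, between 5000 nM and 30000 nM.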

Compound 4, half-maximal inhibitory concentration: 18100 nM
The estimate for compound 4 lay 1.5-fold (0.18 log units) below the measured number, and the stated range covers the measured number.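

In this assay, 3,4-dihydroxyphenyl in place of 3,4-dimethoxyphenyl gives a 1.8-fold higher number from compound 2 to compound 4 (0.25 log units; within the scatter), so on the core of compound 2 the two values cannot be told apart. The same change on the core of compound 1 cannot be read, because compound 1 and compound 3 both give a limit and not a number: the limit of > 20000 nM in this assay, at which 2 of the 4 values shown sit. The series therefore holds one readable instance of this change, which neither confirms nor rules out that the change behaves alike on both cores.

Open, as far as these compounds go, is how this assay reads when an amine or a carboxylic acid stands in place of the 3,4-dihydroxyphenyl on that oxygen. Also open, from the compounds shown here alone, is how a phenyl carrying a single methoxy group reads at the same place, on either core, and whether any such group would give a number on the core of compound 1.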